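Swapping the urea aryl group in a kinase-style inhibitor series

The compounds below may be only part of what the source reports. "The series", "measured", "known", "first", "only" and "open" are said of these compounds alone.

Of the compounds shown here, three share one core and have been tested in a functional assay on MDA-MB-435 cells (Homo sapiens) for inhibition, read by sulforhodamine B assay, with a stated time of 48 h; on this read-out higher numbers stand for weaker inhibition of growth and lower numbers for stronger inhibition of growth. Compound 1 `O=C(Nc1cccc(-n2cc(-c3ccncc3)c(-c3ccc(Cl)c(O)c3)n2)c1)Nc1ccc(Cl)c(Cl)c1` gives 1100 nM, the highest number among the three; compound 2 `COc1cc(-c2nn(-c3cccc(NC(=O)Nc4ccc(Cl)c(C(F)(F)F)c4)c3)cc2-c2ccncc2)ccc1Cl` gives 683 nM, within the scatter of compound 1; compound 3 `COc1cc(-c2nn(-c3cccc(NC(=O)c4ccccc4)c3)cc2-c2ccncc2)ccc1Cl` gives 189 nM. Among the compounds with values here, the only single-point step known, a 3.6-fold lower number from compound 2 to compound 3 (0.56 log units; beyond the scatter), changes the carbonyl side and so does not directly test the change now in question. Compound 4 `O=C(Nc1cccc(-n2cc(-c3ccncc3)c(-c3ccc(Cl)c(O)c3)n2)c1)Nc1cccc(C(F)(F)F)c1` differs from compound 1 by 3-(trifluoromethyl)phenyl in place of 3,4-dichlorophenyl on an amide-type nitrogen. Within the data shown here, with no matching step to lean on, the expectation is for little change, so compound 4 is estimated at 1500 nM, between 500 nM and 4500 nM, an expected step of a 1.4-fold higher number from compound 1 to compound 4 (0.13 log units; within the scatter).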

Compound 4, concentration for 50% growth inhibition: 1490 nM
Compound 4: the middle estimate sits 1.0-fold (0.00 log units) above what was measured; the measured number falls inside the stated range.
By their numbers in this assay, from the lowest: compound 3; then compounds 2, 1 and 4 (each within the scatter of the next, the first and the last beyond it).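

On an amide-type nitrogen of the core of compound 1, 3-(trifluoromethyl)phenyl in place of 3,4-dichlorophenyl gives a 1.4-fold higher number from compound 1 to compound 4 (0.13 log units; within the scatter). Unlike the earlier step, which altered the carbonyl side, this one changes only the aryl group on that nitrogen, and this exchange leaves the number within the scatter. No measurement shown offers an explanation for this result.

On these data alone, what a phenyl ring carrying a carboxylic acid or an amine would give on this nitrogen stays open. So does whether the same swap would read alike on the core of compound 2.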